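Compound 1 to Compound 3: One Group Exchanged

A few compounds are considered here, and "the series" means these few. Any claim that something is new, unique, unknown or untested is made for them only; others in the source may bear on it.

Measured in an ADME assay on microsomes from liver (Mus musculus) for metabolic stability, read by LC-MS, with a stated time of 30 min, tested at 1 uM; on this read-out lower numbers stand for a less stable compound and higher numbers for a more stable compound:
- compound 1 `O=C(NCc1ccc(S(=O)(=O)c2ccccc2)cc1)c1ccc2nccn2c1`: 18%
- compound 2 `O=C(NCc1ccc(S(=O)(=O)N2CCCCC2)cc1)c1cc2cnccc2o1`: 4.6%

Only these two compounds have been measured so far. Compound 1 holds the higher number at 18%, and compound 2 gives 4.6%, a gap beyond the usual scatter. Among the measured compounds shown here, the two differ in more than one place, so they offer no measured step for a single change.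

The next compound, compound 3 `O=C(NCc1ccc(S(=O)(=O)c2ccccc2)cc1)c1cc2cnccc2[nH]1`, keeps the rest of compound 1 and changes only the group on the carbonyl carbon: a group of 9 heavy atoms (7 carbon, 2 nitrogen; one five-membered aromatic ring with 1 hetero atom, one six-membered aromatic ring with 1 hetero atom) in place of a group of 9 heavy atoms (7 carbon, 2 nitrogen; one five-membered aromatic ring with 2 hetero atoms, one six-membered aromatic ring with 1 hetero atom), on a carbonyl carbon. For the measured compounds named here, with no direct precedent, no change beyond the scatter is the expected outcome, and the expected size is a number 4 percentage points lower from compound 1 to compound 3 (within the scatter). In this assay the estimate for compound 3 is 14%, with an expected range of 3% to 35%.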

Compound 3, percent of the compound remaining: 54%
The estimate for compound 3 lay 40 percentage points below the measured number; the measured number lies above the stated range.
By their numbers in this assay, from the lowest: compound 2; then compound 1; then compound 3.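

In this assay, among the compounds shown here, the exchange on the carbonyl carbon gives a number 36 percentage points higher from compound 1 to compound 3 (beyond the scatter), the first single-change step in this set, and it shows that this position can strongly affect the read-out. The change need not alter the heavy-atom count or composition, since the two groups have the same atoms joined differently. They differ in their rings, with one hetero atom rather than two in the five-membered aromatic ring, and in their counts of hydrogen-bond donors and acceptors, but no measurement shown here explains the step.

With a single step at this position, the compounds shown leave open which of these differences matters, and a methyl group in place of the ring hydrogen of the entering group would bear on that question. They also leave open whether the step would carry over if the phenyl group on the sulfonyl were exchanged for an amine.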